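Swapping Hydroxymethyl for Acetyl: What to Expect

The source may hold more compounds than are shown below. What is called first, only, known or untested is meant among the compounds shown, and "the series" means these compounds.

Compound 1, `Oc1cccc2cc(-c3ccccc3)ccc12`: in an assay for binding affinity to 17-beta-hydroxysteroid dehydrogenase type 1 (Homo sapiens), with a stated time of 20 min, tested at 1 uM (on this read-out lower numbers stand for less inhibition and higher numbers for more inhibition at the one concentration tested (going by the name of the read-out)), compound 1 gives < 10%, which is a limit of the assay and not a number.
Compound 2, `OCc1ccc(-c2ccc3c(O)cccc3c2)cc1`: in this assay compound 2 gives 14%.
Compound 3, `Oc1cccc2cc(-c3ccc(F)cc3)ccc12`: in this assay compound 3 gives < 10%, again a limit of the assay and not a number.

Compound 2 thus stands as the only one of the three with an actual number; the other two sit at the limit of < 10% in this assay, at which 2 of the 3 values shown sit. Compound 4, `CC(=O)c1ccc(-c2ccc3c(O)cccc3c2)cc1`, differs from compound 2 in a single place: acetyl in place of hydroxymethyl on an aromatic carbon. Going by the values given here, two measured steps touch that same place. The step of a number at least 4 percentage points higher from compound 1 to compound 2 (that floor lies within the scatter) and the step of a number at least 4 percentage points lower from compound 2 to compound 3 (that floor lies within the scatter) both show changes at this position moving the read-out only within the scatter, with compound 2 just above the two limits. Acetyl itself has not been measured here. The step of a number 4 percentage points lower from compound 2 to compound 4 (within the scatter) is therefore expected to stay within the scatter. Compound 4 is estimated at 10%, ranging from 0% to 24%, with a fair chance that only a limit is reported.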

Compound 4, a percentage reported as inhibition, at one concentration (the size of the read-out at that concentration, not a potency): 16%
Compound 4: the middle estimate sits 6 percentage points below what was measured, within the range that was stated.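

Compound 4 gives this position a second real number, so two groups can now be compared directly rather than against limits. In this assay, acetyl in place of hydroxymethyl gives a number 2 percentage points higher from compound 2 to compound 4 (within the scatter), so this swap, in which a hydrogen-bond donor leaves and none enters, shows no readable change in this pair. Against the other two compounds, acetyl in place of hydrogen gives a number at least 6 percentage points higher from compound 1 to compound 4 (that floor lies within the scatter) and acetyl in place of fluoro gives a number at least 6 percentage points higher from compound 3 to compound 4 (that floor lies within the scatter), but these are only floors and the true sizes stay unknown, with the low end of the read-out still crowded: the limit of < 10% in this assay, at which 2 of the 4 values shown sit.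

No step among these four compounds is shown to lie beyond the scatter. On these data alone, whether an amine, a carboxylic acid or a longer chain at this position would do so remains open.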